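From Cyclopentyl to Butyl on a Sulfur

This account rests on a few compounds, and the source may have more. Where it says the series, first, only, none or still open, it means among the compounds named here.

In an ADME assay on CCRF-HSB-2 cells (Homo sapiens) for cytotoxicity, with a stated time of 7 days (on this read-out higher numbers stand for lower toxicity in this test and lower numbers for higher toxicity in this test), compound 2 `Nc1nc(SC2CCCC2)c2ncn(/C=C3/CC3(CO)CO)c2n1` gives 91000 nM. Compound 1 `CC(C)Sc1nc(N)nc2c1ncn2/C=C1/CC1(CO)CO` gives 94000 nM, so the two values lie within the scatter of each other, and compound 2 has no other neighbour on this scale. Compound 3 `CCCCSc1nc(N)nc2c1ncn2/C=C1/CC1(CO)CO` keeps the shared core and alters only the group on the sulfur: butyl in place of cyclopentyl on a sulfur. In other words, it has butyl in place of cyclopentyl on a sulfur. Going by the values given here, the sole measured guide is a 1.0-fold lower number from compound 1 to compound 2 (0.01 log units; within the scatter), where cyclopentyl took the place of isopropyl on that same sulfur. One step is thin evidence, but it gives no ground for expecting a change beyond the scatter in this assay. The expected move is a 1.0-fold lower number from compound 2 to compound 3 (0.00 log units; within the scatter). For compound 3 the estimated value is 90000 nM, with an expected range of 45000 nM to 170000 nM.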

Compound 3, half-maximal cytotoxic concentration: 89000 nM
Beside the measured number, compound 3's estimate is 1.0-fold (0.00 log units) above it; the measured number falls inside the stated range.
By their numbers in this assay, from the lowest: compounds 3, 2 and 1 (each within the scatter of the next).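

Going by these compounds alone, compound 3 is the first compound here with an open chain on this sulfur, and in this assay the ring can give way to that chain with no change beyond the scatter (a 1.0-fold lower number from compound 2 to compound 3 (0.01 log units; within the scatter)). The same holds when butyl is set against isopropyl (a 1.1-fold lower number from compound 1 to compound 3 (0.02 log units; within the scatter)), so all three groups on this sulfur, butyl, cyclopentyl and isopropyl, give values within the scatter of one another in this cell test. No measurement is available that would explain this flat result.

From the compounds shown here alone, all three of these groups are built of carbon only, so it remains open whether a longer chain such as octyl, or a chain ending in an amine or a carboxylic acid, would stay within the scatter. Also open, going by these compounds, is what happens if an oxygen takes the place of the sulfur itself.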